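The compounds below may be only part of what the source reports. "The series", "measured", "known", "first", "only" and "open" are said of these compounds alone.

Measured compounds in an ADME assay on HEK293 cells (Homo sapiens) for cytotoxicity, read by CellTiter-Glo and resazurin assay, with a stated time of 72 h; a higher number here means that more compound is needed for the effect, a lower number that less compound is needed:
- compound 1 `CC(=O)c1cccc(-c2ccc(C(=O)N(Cc3cccc(OCCCCCC(=O)O)c3)C(C)C)cc2)c1` — only a limit of the assay, > 26000 nM
- compound 2 `CC(C)N(Cc1cccc(OCCCCCC(=O)O)c1)C(=O)c1ccc(-c2ccsc2)cc1` — only a limit of the assay, > 26000 nM

Compound 2 therefore stands at a limit, not a number. The step that the two limits leave unreadable from compound 1 to compound 2 cannot be sized, because both values sit at the limit of > 26000 nM in this assay, at which 2 of the 2 values shown sit. Compound 3 `Cc1nnc(-c2cccc(-c3ccc(C(=O)N(Cc4cccc(OCCCCCC(=O)O)c4)C(C)C)cc3)c2)o1` is not yet measured; it differs from compound 2 by 3-(5-methyl-1,3,4-oxadiazol-2-yl)phenyl in place of thiophen-3-yl on an aromatic carbon. Going by the values given here, the only measured step that bears on this change is the unreadable one, so it gives no guide to direction or size. Compound 3 is expected to give about 40000 nM in this assay, with a range of 15000 nM to 120000 nM, most likely again reported only as a limit.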

Compound 3, half-maximal effective concentration: > 26000 nM
Compound 3: no number, only a limit (the forecaster's own chance of this, stated with the estimate: 80%); the middle value is on the limit's open side.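

No step between compound 1, compound 2 and compound 3 can be read in this assay, because each gives only a limit of the assay, not a number: the limit of > 26000 nM in this assay, at which 3 of the 3 values shown sit.
As far as these compounds go, whether their differing groups change the concentration needed for the effect remains open.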